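This account rests on a few compounds, and the source may have more. Where it says the series, first, only, none or still open, it means among the compounds named here.

Of the compounds shown here, three that share one core have been measured in a functional assay on DU-145 cells (Homo sapiens) for inhibition, read by trypan blue exclusion, with a stated time of 96 h; a higher number here means a weaker inhibitor of growth, a lower number a stronger inhibitor of growth. Compound 1 (`COc1ccccc1/C=C(\C(=O)c1ccc(Cl)cc1)S(=O)(=O)c1ccc(C)cc1`) gives 1000 nM, and compound 3 (`COc1ccccc1/C=C(\C(=O)c1ccc(Cl)cc1)S(=O)(=O)Cc1ccc(C)cc1`) gives 10000 nM. Compound 2 (`COc1ccccc1/C=C(\C(=O)c1ccc(Cl)cc1)S(=O)(=O)Cc1ccc(Cl)cc1`) gives 25000 nM, the highest number of the three, which makes it the weakest inhibitor of growth in this small set.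

Compound 4 (`Cc1ccc(/C=C(\C(=O)c2ccc(Cl)cc2)S(=O)(=O)Cc2ccc(Cl)cc2)s1`) departs from compound 2 at a new place: 5-methylthiophen-2-yl in place of 2-methoxyphenyl on a double-bonded chain carbon bound to a double-bonded chain carbon. Within the data shown here, no measured step touches that place, so the evidence is only indirect. Replacing the 4-methylphenyl on the sulfonyl sulfur gives a 25-fold higher number from compound 1 to compound 2 (1.40 log units; beyond the scatter) with 4-chlorobenzyl and a 10-fold higher number from compound 1 to compound 3 (1.00 log units; beyond the scatter) with 4-methylbenzyl. Methyl in place of chloro on an aromatic carbon gives a 2.5-fold lower number from compound 2 to compound 3 (0.40 log units; beyond the scatter). These steps show that a single change can move the numbers in this set beyond the scatter, but they do not show which way the new change will go.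

A modest step in this assay is therefore expected, leaning tentatively towards a lower number because compound 2 stands at 25000 nM, the top of the measured range. The expected change is a 2.1-fold lower number from compound 2 to compound 4 (0.32 log units; beyond the scatter). For compound 4, the estimated value is 12000 nM, with an expected range from 2500 nM to 50000 nM.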

Compound 4, concentration for 50% growth inhibition: 1000 nM
For compound 4 the middle estimate is 12-fold (1.08 log units) above the measured one, and the stated range ends above it.
By their numbers in this assay, from the lowest: compounds 1 and 4 (each within the scatter of the next); then compound 3; then compound 2.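

The group on the double-bonded chain carbon bound to a double-bonded chain carbon proves to matter a great deal: in this assay, 5-methylthiophen-2-yl in place of 2-methoxyphenyl gives a 25-fold lower number from compound 2 to compound 4 (1.40 log units; beyond the scatter) and so matches in size a 25-fold higher number from compound 1 to compound 2 (1.40 log units; beyond the scatter) on the sulfonyl side. Among these compounds, the sulfonyl sulfur is therefore not the only place where a single change moves the number far, and this change goes towards a stronger inhibitor of growth, which none of the earlier steps away from compound 1 did. No measurement offered here bears on why this step is so large.

The change replaces a six-membered ring of carbon only with a five-membered ring holding a sulfur, and a methoxy group with a methyl group, all at once, so the compounds shown cannot tell which part carries the step; a plain phenyl or an unsubstituted thiophen-2-yl at this place would begin to separate them. Also open, going by these compounds, is whether the step would hold with the 4-methylphenyl on the sulfonyl sulfur, or with an amine or a carboxylic acid on the ring.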